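The source may report more compounds than this note shows. Statements on the series, on what has been measured and on what is new or still open speak of the compounds shown alone.

Compound 1, `Oc1cccc(-c2cc(-c3cccc(F)c3)cc(-c3ccccc3O)n2)c1`. In a functional assay on HeLa cells (Homo sapiens) for inhibition (on this read-out higher numbers stand for weaker inhibition and lower numbers for stronger inhibition), compound 1 gives > 50000 nM, which is a limit of the assay.
Compound 2, `Oc1cccc(-c2cc(-c3cccc(OC(F)(F)F)c3)cc(-c3ccccc3O)n2)c1`. In this assay compound 2 gives 14900 nM.

Going by the values given here, compound 2 thus holds the only number among the two values shown; the other value is a limit, namely (the limit of > 50000 nM in this assay, at which 1 of the 2 values shown sits). Among the compounds with values here, the single measured step is an at least 3.3-fold lower number from compound 1 to compound 2 (0.52 log units; beyond the scatter), a change on the trifluoromethoxy-bearing ring. Compound 3, `Oc1ccc(-c2cc(-c3cccc(OC(F)(F)F)c3)cc(-c3cccc(O)c3)n2)cc1`, differs from compound 2 at another place: 4-hydroxyphenyl in place of 2-hydroxyphenyl on an aromatic carbon. The measured step does not touch this position, so it offers no direct guide to the size or direction of the change from compound 2 to compound 3 in this assay; the account therefore expects a step within the scatter, with the estimated step being a 1.2-fold higher number from compound 2 to compound 3 (0.08 log units; within the scatter). On that basis compound 3 is expected to give about 18000 nM in this assay, in a range from 6000 nM to 55000 nM.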

Compound 3, half-maximal inhibitory concentration: 14100 nM
For compound 3 the middle estimate is 1.3-fold (0.11 log units) above the measured one; the range from low to high includes it.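

In this assay, 4-hydroxyphenyl in place of 2-hydroxyphenyl on the aromatic carbon next to the ring nitrogen gives a 1.1-fold lower number from compound 2 to compound 3 (0.02 log units; within the scatter), so the two compounds cannot be told apart. Going by these compounds alone, the earlier step concerned only the trifluoromethoxy-bearing ring, and this is the first reading at this position: with trifluoromethoxy kept, the two hydroxyphenyl isomers read alike. Nothing measured here bears on why the two isomers read alike.

The compounds shown leave open whether this position would stay as unresponsive if the hydroxyl gave way to an amine or a carboxylic acid. They also leave open whether the same swap would read alike with fluoro on the other ring, the group carried by compound 1, whose value is a limit.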